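Trading the Dimethoxyphenyl for Ethyl on the Ring Nitrogen

The source may hold more compounds than are shown below. What is called first, only, known or untested is meant among the compounds shown, and "the series" means these compounds.

Measured so far:
compound 1 `COc1ccccc1N1C(=O)CSC1c1cc(F)cc(C(=O)O)c1`: 0%
compound 2 `COc1cccc(OC)c1N1C(=O)CSC1c1cccc(C(=O)NCCCCc2ccccc2)c1`: 31%
compound 3 `O=C(NCCCCc1ccccc1)c1cccc(C2OCC(=O)N2c2cccc(F)c2)c1`: 0%

In a functional assay on 143B cells (Homo sapiens) for inhibition, read by CCK-8 assay, with a stated time of 72 h, tested at 1 uM (on this read-out lower numbers stand for less inhibition and higher numbers for more inhibition at the one concentration tested (going by the name of the read-out)), compound 2 gives 31%, the highest of the three numbers. Among the measured compounds shown here, compound 1 gives 0% and compound 3 gives 0%; both of these lie below compound 2 by a gap beyond the usual scatter, so compound 2 is the only compound of the three with inhibition that can be read as real. For the measured compounds named here, no pair of measured compounds differs in a single place, so no measured step is available to guide what follows.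

Compound 4 `CCN1C(=O)CSC1c1cccc(C(=O)NCCCCc2ccccc2)c1` has not yet been measured. It differs from compound 2 in one place: ethyl in place of 2,6-dimethoxyphenyl on an amide-type nitrogen in a ring. Every measured compound carries an aromatic ring on that ring nitrogen, and only the 2,6-dimethoxyphenyl of compound 2 goes with measurable inhibition; compound 1 and compound 3 carry other aromatic groups and give none. Going by the values given here, no measured compound carries an alkyl group there, so the expectation rests on the value of compound 2 alone. Because compound 2 gives 31% and the group that leaves is the one that sets it apart, a downward step beyond the scatter is expected, a number 21 percentage points lower from compound 2 to compound 4 (beyond the scatter). Compound 4 is therefore estimated at 10%, within a range from 0% to 30%.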

Compound 4, a percentage reported as inhibition, at one concentration (the size of the read-out at that concentration, not a potency): 40%
The estimate for compound 4 lay 30 percentage points below the measured number, outside the stated range (above it).
By their numbers in this assay, from the lowest: compounds 1 and 3 (each within the scatter of the next); then compounds 2 and 4 (each within the scatter of the next).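

In this assay, putting ethyl in place of 2,6-dimethoxyphenyl on the amide-type nitrogen in the ring gives a number 9 percentage points higher from compound 2 to compound 4 (within the scatter), so the two compounds cannot be told apart on this read-out. Among the compounds shown here, this is the first single-place comparison, and it shows that the inhibition seen with compound 2 does not depend on an aromatic ring at this position: the group of 10 heavy atoms, with its six-membered aromatic ring and 2 hydrogen-bond acceptors, gives way to one of 2 heavy atoms with no ring and no hydrogen-bond acceptors, and the number stays within the scatter. Nothing at hand explains why the position accepts so large a change.

The compounds shown leave open whether a longer chain such as butyl, a chain ending in an amine or a carboxylic acid, or a plain hydrogen on that nitrogen would keep the number where it stands. They also leave open how compound 2 and compound 4 would compare across a range of concentrations, as each was read at a single one.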